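The source may report more compounds than this note shows. Statements on the series, on what has been measured and on what is new or still open speak of the compounds shown alone.

Compounds measured in a functional assay on K562 cells (Homo sapiens) for antiproliferative activity, read by MTT assay, with a stated time of 72 h; on this read-out lower numbers stand for stronger inhibition and higher numbers for weaker inhibition:
- compound 1, `COc1cc(-n2ncnc2-c2ccc(F)cc2)cc(OC)c1OC`, gives > 10000 nM
- compound 2, `CCOc1ccccc1-c1ncnn1-c1cc(OC)c(OC)c(OC)c1`, gives > 10000 nM
- compound 3, `COc1cc(-c2ncnn2-c2ccc([N+](=O)[O-])cc2)cc(OC)c1OC`, gives > 10000 nM

Each of these three values is a limit of the assay and not a number. The value for compound 1 is a limit, (the limit of > 10000 nM in this assay, at which 3 of the 3 values shown sit), so compound 1 cannot be placed above or below any of the other two; all that the numbers show is that none of the three compounds reaches a measurable half-maximal inhibitory concentration in this assay. Within the data shown here, no step between two measured compounds that differ in one place is available, so the size of the change that any single substitution brings is unknown from this set.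

Compound 4, `COc1cc(-n2ncnc2-c2cccc(Cl)c2)cc(OC)c1OC`, has not yet been measured. It differs from compound 1 in one place: 3-chlorophenyl in place of 4-fluorophenyl on an aromatic carbon. Among the measured compounds shown here, with compound 1 resting at a limit and no measured step to lean on, the expected step that the limit leaves unreadable from compound 1 to compound 4 is no change beyond the scatter, since nothing here shows that such a swap moves the read-out. Compound 4 is therefore estimated at 15000 nM, in a range from 5000 nM to 50000 nM, with the most likely outcome again a limit rather than a number.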

Compound 4, half-maximal inhibitory concentration: > 10000 nM
Compound 4: only a limit was reported (the forecaster's own chance of this, stated with the estimate: 85%); the middle value does not contradict the limit.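

In this assay compound 4 gives > 10000 nM, which is a limit and not a number. Compound 1 also rests at a limit, so no step can be read between compound 1 and compound 4: the limit of > 10000 nM in this assay, at which 4 of the 4 values shown sit.

The compounds shown leave open whether any change to the shared core gives a measurable half-maximal inhibitory concentration.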